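A few compounds are considered here, and "the series" means these few. Any claim that something is new, unique, unknown or untested is made for them only; others in the source may bear on it.

Working notes on the series. In a functional assay on MDA-MB-436 cells (Homo sapiens) for antiproliferative activity, read by MTT assay, with a stated time of 48 h (on this read-out lower numbers stand for stronger inhibition and higher numbers for weaker inhibition), compound 1 `C=CS(=O)(=O)N1CCN(c2ncnc3sc(-c4ccc(OC)cc4)cc23)CC1` gives 28400 nM, compound 2 `C=CS(=O)(=O)N1CCN(c2ncnc3sc(-c4cccc5ncccc45)cc23)CC1` gives 25900 nM and compound 3 `C=CS(=O)(=O)N1CCN(c2ncnc3sc(-c4c(C)noc4C)cc23)CC1` gives 34600 nM. Compound 3 therefore stands within the scatter of both other compounds, and the three sit at one level.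

Compound 4 `C=CS(=O)(=O)N1CCN(c2ncnc3sc(C4=CCCCC4)cc23)CC1` keeps the shared core and changes only the group on the aromatic carbon: cyclohex-1-en-1-yl in place of 3,5-dimethyl-1,2-oxazol-4-yl on an aromatic carbon. Three measured exchanges at this same place bear on the change: a 1.1-fold lower number from compound 1 to compound 2 (0.04 log units; within the scatter), a 1.2-fold higher number from compound 1 to compound 3 (0.09 log units; within the scatter) and a 1.3-fold higher number from compound 2 to compound 3 (0.13 log units; within the scatter). None goes beyond the scatter, even though the groups exchanged differ considerably. Among the compounds with values here, no measured compound carries a non-aromatic ring of carbon only at this place, so these steps offer only indirect guidance and the range is kept wide.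

Resting on compound 3 at 34600 nM and on those three steps, no change beyond the scatter is expected in this assay. The estimated step is a 1.2-fold lower number from compound 3 to compound 4 (0.06 log units; within the scatter). For compound 4 the expected value is 30000 nM, with an estimated range of 14000 nM to 60000 nM.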

Compound 4, half-maximal inhibitory concentration: > 50000 nM
Compound 4 gave a limit, no number; the forecaster's own chance of this, stated with the estimate: 8%; middle value at least 1.6-fold (0.22 log units) away from the limit.
By their numbers in this assay, from the lowest: compounds 2, 1 and 3 (each within the scatter of the next). At a limit, above all of these: compound 4.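

In this assay, compound 4 gives a limit and not a number: the limit of > 50000 nM in this assay, at which 1 of the 4 values shown sits. The steps can be read only as floors, an at least 1.4-fold higher number from compound 3 to compound 4 (0.15 log units; that floor lies within the scatter), an at least 1.9-fold higher number from compound 2 to compound 4 (0.28 log units; that floor lies within the scatter) and an at least 1.7-fold higher number from compound 1 to compound 4 (0.24 log units; that floor lies within the scatter), so they establish no separation from the other three compounds. Even so, cyclohex-1-en-1-yl, a non-aromatic ring of carbon only, is the one group shown at this place, on an aromatic carbon next to the ring sulfur, that yields no number, whereas the three aromatic groups all do.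

From the compounds shown here alone, the true size of these steps stays open, as does whether the lack of aromaticity or the double bond matters, a question that saturated cyclohexyl would address. Also open, going by these compounds, is whether an amine such as piperidin-4-yl, or a carboxylic acid on an aromatic ring, would bring the number below the level of compounds 1, 2 and 3.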